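Bromoacrylamide chalcones in HeLa cells: methoxy steps

The source may report more compounds than this note shows. Statements on the series, on what has been measured and on what is new or still open speak of the compounds shown alone.

Measured so far:
compound 1, `C=C(Br)C(=O)Nc1ccc(C(=O)/C=C/c2ccccc2)cc1`, gives 960 nM
compound 2, `C=C(Br)C(=O)Nc1ccc(C(=O)/C=C/c2ccccc2OC)cc1`, gives 1300 nM
compound 3, `C=C(Br)C(=O)Nc1ccc(C(=O)/C=C/c2cc(OC)cc(OC)c2)cc1`, gives 1700 nM

All three numbers come from a functional assay on HeLa cells (Homo sapiens) for antiproliferative activity, with a stated time of 48 h; a higher number here means a weaker inhibitor, a lower number a stronger inhibitor. Compound 2 differs from compound 1 by methoxy in place of hydrogen on an aromatic carbon, and that change gave a 1.4-fold higher number from compound 1 to compound 2 (0.13 log units; within the scatter). Compound 3 differs from compound 1 in more than one place, so the difference between the two cores is not broken down here; the numbers of compound 1 and compound 3 lie within the scatter of each other, as do those of compound 2 and compound 3. For the measured compounds named here, no compound among the three can be called stronger or weaker than another on these data.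

Compound 4, `C=C(Br)C(=O)Nc1ccc(C(=O)/C=C/c2cc(OC)c(OC)c(OC)c2)cc1`, has not yet been measured. It differs from compound 3 by methoxy in place of hydrogen on an aromatic carbon. Going by the values given here, this is the same kind of change as the one made from compound 1 to compound 2, but the surroundings differ: in compound 2 the entering methoxy sits ortho to a large group, whereas in compound 4 it sits ortho to two methoxy groups and para to a large group. Because the same kind of change earlier gave a 1.4-fold higher number from compound 1 to compound 2 (0.13 log units; within the scatter), compound 4 is expected to show a step of a 1.2-fold higher number from compound 3 to compound 4 (0.07 log units; within the scatter) in this assay. The expectation is a number near the parent, with the range widened for the changed surroundings. Compound 4 is estimated at 2000 nM, between 900 nM and 4500 nM.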

Compound 4, half-maximal inhibitory concentration: 420 nM
Estimate against measurement, compound 4: 4.8-fold (0.68 log units) above; the whole stated range lies above it.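

In this assay, methoxy in place of hydrogen on an aromatic carbon gave a 4.0-fold lower number from compound 3 to compound 4 (0.61 log units; beyond the scatter), a step that is modest but lies beyond the scatter. This change therefore cannot be carried from one core to another in this series as a single fixed step, since the two cases differ in size and only the later step can be read as a real change: the same change on two cores in this assay, a 1.4-fold higher number (0.13 log units; within the scatter) from compound 1 to compound 2 and a 4.0-fold lower number (0.61 log units; beyond the scatter) from compound 3 to compound 4, 5.5-fold (0.74 log units) apart, beyond the scatter of two such steps What this does not show is which difference in surroundings sets the two steps apart, as the entering methoxy sits ortho to a large group in compound 2 but ortho to two methoxy groups and para to a large group in compound 4, and two steps cannot separate these features or predict the step on a further core.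

On these data alone, it remains open whether a hydroxyl, an ethoxy or an amine at the position taken by the entering methoxy of compound 4 would give a number like that of compound 4 or like that of compound 3. As far as these compounds go, all four compounds carry the same bromoacrylamide part, so it is also open whether the step would persist with a plain acrylamide in its place.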